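The compounds below may be only part of what the source reports. "The series", "measured", "known", "first", "only" and "open" are said of these compounds alone.

Values so far in a physicochemical assay for lipophilicity, at pH 7.4, tested at 10 mM; a lower number here means a more polar compound, a higher number a more lipophilic compound
compound 1 `Cc1nn(-c2ccccc2)c(SSc2c(C(=O)c3ccccc3)c(C)nn2-c2ccccc2)c1C(=O)c1ccccc1` gives 8
compound 2 `Cc1cc(COc2cc(C)nn2-c2ccccc2)n(-c2ccccc2)n1` gives 2.2
compound 3 `Cc1cc(OCCOc2cc(C)nn2-c2ccccc2)n(-c2ccccc2)n1` gives -1.6

Compound 2 stands second highest of these three numbers, with compound 3 lower and compound 1 higher, and both gaps lie beyond the usual scatter. The next compound to be read is compound 4 `Cc1cc(OCc2cc(C)nn2-c2ccccc2)[nH]n1`, which has no value yet. Its difference from compound 2 is hydrogen in place of phenyl on an aromatic nitrogen, in words hydrogen in place of phenyl on an aromatic nitrogen.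

Among the compounds with values here, no pair of measured compounds differs in one place, so the series offers no direct step for this change. The measured values show only a wide spread, from compound 3 at -1.6 to compound 1 at 8, and they do not separate the effect of any single group. The expectation therefore rests on the structural change alone: a drop in this assay beyond the scatter, with a ring of carbon only leaving and nothing but hydrogen entering. The estimated change is a number 1.40 log units lower from compound 2 to compound 4 (beyond the scatter), and its size is uncertain. Compound 4 is expected at 0.8, with an estimated range of -0.6 to 2.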

Compound 4, distribution coefficient: 2.9
Estimate against measurement, compound 4: 2.10 log units below; measured number above the stated range.
By their numbers in this assay, from the lowest: compound 3; then compound 2; then compound 4; then compound 1.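

Hydrogen in place of phenyl on an aromatic nitrogen gives the first direct step in this series: in this assay the change reads a number 0.70 log units higher from compound 2 to compound 4 (beyond the scatter) and is modest in size. The earlier compounds shown here, none of which differ in one place, could show only a wide spread of values and nothing about this position taken alone. The step now shows that on this aromatic nitrogen, with the methyl group and the rest of the structure held fixed, losing a six-membered aromatic ring of carbon only, with its 6 heavy atoms, does not lower the number in this assay for this pair, and nothing in the material given accounts for that direction.

Open, from the compounds shown here alone, is how other groups on this aromatic nitrogen would read, such as methyl, a longer chain like butyl, or a phenyl carrying an amine or a carboxylic acid. Also open, going by these compounds, is whether the same change would give a step of similar direction and size on the phenyl that compound 4 keeps, or in the setting of compound 1 or compound 3.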